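The source may hold more compounds than are shown below. What is called first, only, known or untested is meant among the compounds shown, and "the series" means these compounds.

Compound 2 `CCn1c(C(=O)NCC#N)ccc1C(CC)(CC)c1ccc(OCCC(O)(CC)CC)c(C)c1` has the highest number of the two compounds measured in a functional assay on PC-3 cells (Homo sapiens) for antiproliferative activity, read by MTT assay, with a stated time of 48 h (on this read-out lower numbers stand for stronger inhibition and higher numbers for weaker inhibition), giving 17800 nM. Its nearest neighbour, compound 1 `CCn1c(C(=O)NCCN(C)C)ccc1C(CC)(CC)c1ccc(OCCC(O)(CC)CC)c(C)c1`, gives 870 nM in this assay. Among the compounds with values here, the one measured step, a 20-fold higher number from compound 1 to compound 2 (1.31 log units; beyond the scatter), shows that the group on the amide nitrogen matters greatly here. Compound 3 `C=CCN(C)C(=O)c1ccc(C(CC)(CC)c2ccc(OCCC(O)(CC)CC)c(C)c2)n1CC` carries allyl(methyl)amino in place of (cyanomethyl)amino on a carbonyl carbon, so the nitrile of compound 2 is gone, but nothing like the (dimethylamino)methyl of compound 1 returns. The estimate for compound 3 is therefore a move back toward compound 1 of a 3.6-fold lower number from compound 2 to compound 3 (0.55 log units; beyond the scatter), expected at 5000 nM with a range from 1500 nM to 16000 nM.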

Compound 3, half-maximal inhibitory concentration: 12800 nM
Estimate against measurement, compound 3: 2.6-fold (0.41 log units) below; low and high end bracket the measured number.
By their numbers in this assay, from the lowest: compound 1; then compounds 3 and 2 (each within the scatter of the next).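

In this assay, allyl(methyl)amino in place of (cyanomethyl)amino on a carbonyl carbon gives a 1.4-fold lower number from compound 2 to compound 3 (0.14 log units; within the scatter) and so stays within the scatter, although the nitrile and the amide hydrogen are both gone. Only the (2-(dimethylamino)ethyl)amino group of compound 1 stands apart so far, as its replacement gives a 15-fold higher number from compound 1 to compound 3 (1.17 log units; beyond the scatter) for the same allyl(methyl)amino group. No measurement here accounts for this difference. Open, as far as these compounds go, is whether the dimethylamino end or the amide hydrogen of compound 1 matters more; a primary amine or a longer chain ending in dimethylamino could separate them.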